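This account rests on a few compounds, and the source may have more. Where it says the series, first, only, none or still open, it means among the compounds named here.

Compound 1 `Cc1ccc(NC(=O)CN2CCN(c3nnc(Cc4ccncc4)c4ccccc34)CC2)c(C)c1`, compound 2 `O=C(CN1CCN(c2nnc(Cc3ccncc3)c3ccccc23)CC1)Nc1cccc(Br)c1` and compound 3 `O=C(CN1CCN(c2nnc(Cc3ccccc3)c3ccccc23)CC1)Nc1cccc(Br)c1` were tested in a functional assay on HT-29 cells (Homo sapiens) for cytotoxicity, read by MTT assay, with a stated time of 72 h; on this read-out higher numbers stand for weaker inhibition and lower numbers for stronger inhibition. In this assay compound 2 gives 1350 nM, compound 1 gives 1930 nM and compound 3 gives 13400 nM. The change 2,4-dimethylphenyl in place of 3-bromophenyl on an amide-type nitrogen made the step of a 1.4-fold higher number from compound 2 to compound 1 (0.16 log units; within the scatter). The cores of compound 2 and compound 3 differ by phenyl in place of pyridin-4-yl on a saturated chain carbon bound to an aromatic carbon, which made the step of a 9.9-fold higher number from compound 2 to compound 3 (1.00 log units; beyond the scatter). Compound 4 `Cc1ccc(NC(=O)CN2CCN(c3nnc(Cc4ccccc4)c4ccccc34)CC2)c(C)c1` has not yet been measured in this assay; it stands to compound 3 as compound 1 stands to compound 2, the same change 2,4-dimethylphenyl in place of 3-bromophenyl on an amide-type nitrogen at the same place on an amide-type nitrogen. Since the same change gave a 1.4-fold higher number from compound 2 to compound 1 (0.16 log units; within the scatter), the step from compound 3 to compound 4 is expected to be similar, a 1.3-fold higher number from compound 3 to compound 4 (0.13 log units; within the scatter), within the scatter. Compound 4 is therefore estimated to give 18000 nM in this assay, between 8000 nM and 40000 nM.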

Compound 4, half-maximal inhibitory concentration: "not active" (no number reported)
No number was reported for compound 4; the estimate stays without a comparison.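

For the compounds shown here, compound 4 was reported as "not active" in this assay, with no number, so no step from compound 3 to compound 4 can be read. The compounds shown leave open how far 2,4-dimethylphenyl in place of 3-bromophenyl shifts the number when phenyl replaces pyridin-4-yl, and no other data here bear on this result.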